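A Methoxyethyl Phenyl Ether Examined for Liver Cell Toxicity

The source may hold more compounds than are shown below. What is called first, only, known or untested is meant among the compounds shown, and "the series" means these compounds.

compound 1, `O=C(Nc1ncc(Cc2ccc(F)cc2)s1)c1ccccc1`: "not toxic" (no number reported)
compound 2, `Cc1ccc(C(=O)Nc2ncc(Cc3ccc(F)cc3)s2)cc1`: "not toxic" (no number reported)
compound 3, `Cc1cc(C(C)C)ccc1OC(c1ccc(Cl)cc1)c1cnc(NC(=O)OC(C)(C)C)s1`: > 50000 nM

Three compounds have been run in an ADME assay on HepG2 2.2.15 cells (Homo sapiens) for cytotoxicity; on this read-out lower numbers stand for higher toxicity in this test and higher numbers for lower toxicity in this test. Compound 1 and compound 2 are each recorded only as not toxic, with no number attached to either. For compound 3 the result is a limit of the assay, > 50000 nM, and not a measured number. On what is shown, compound 3 therefore stands at the limit of > 50000 nM in this assay, at which 1 of the 3 values shown sits, the least toxic position the test reports, with nothing in the set more toxic to compare it against.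

Compound 4, `COCCc1ccc(OC(c2ccc(Cl)cc2)c2cnc(NC(=O)OC(C)(C)C)s2)cc1`, differs from compound 3 in one place: 4-(2-methoxyethyl)phenyl in place of 4-isopropyl-2-methylphenyl on an oxygen on a saturated carbon. Among the measured compounds shown here, no step between two measured compounds covers a change of this kind, so the data give no size for it.

The author expects the step that the limit leaves unreadable from compound 3 to compound 4 to remain within the scatter, because compound 3 already rests at the limit of > 50000 nM in this assay, at which 1 of the 3 values shown sits, and the shown set contains no toxic member. Compound 4 is accordingly estimated at 60000 nM, in a range from 30000 nM to 150000 nM, most probably reported once more as a limit.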

Compound 4, half-maximal cytotoxic concentration: > 50000 nM
Compound 4 gave a limit, no number; the forecaster's own chance of this, stated with the estimate: 75%; the middle value does not contradict the limit.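

In this assay, among the compounds shown here, compound 3 and compound 4 both end at a limit of the assay and not at a number, so no step between them can be read: the limit of > 50000 nM in this assay, at which 2 of the 4 values shown sit. The compounds shown leave open how far 4-(2-methoxyethyl)phenyl and 4-isopropyl-2-methylphenyl differ on this read-out.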